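A methyl added to the phenyl of compound 3

A few compounds are considered here, and "the series" means these few. Any claim that something is new, unique, unknown or untested is made for them only; others in the source may bear on it.

In a functional assay on DLD-1 cells (Homo sapiens) for antiproliferative activity, read by CellTiter-Glo, with a stated time of 72 h (a higher number here means a weaker inhibitor, a lower number a stronger inhibitor), compound 3 `Cc1cc(C)c(S(=O)(=O)N2CCC(c3ccccc3)CC2)c(C)c1` reports only a limit, > 5000 nM. Compound 1 `Cc1cc(C)c(S(=O)(=O)N2CCC(C3OCC(C)CO3)CC2)c(C)c1` likewise sits at a limit, > 5000 nM. Compound 2 `Cc1cc(C)c(S(=O)(=O)N2CCC(N3CCC(C)OC3)CC2)c(C)c1` gives 92 nM, so that an at least 54-fold lower number from compound 1 to compound 2 (1.73 log units; beyond the scatter) and an at least 54-fold higher number from compound 2 to compound 3 (1.73 log units; beyond the scatter), while a step that the two limits leave unreadable from compound 1 to compound 3. Two of the three values thus rest at the limit of > 5000 nM in this assay, at which 2 of the 3 values shown sit. Compound 4 `Cc1ccc(C2CCN(S(=O)(=O)c3c(C)cc(C)cc3C)CC2)cc1` differs from compound 3 by methyl in place of hydrogen on an aromatic carbon. Among the compounds with values here, no measured step concerns a methyl on the aromatic ring; every known step exchanges the whole ring on the saturated ring carbon, and the carbon-only aromatic ring of compound 3 reached only the limit. Compound 4 is therefore expected to stay near that limit, with a step that the limit leaves unreadable from compound 3 to compound 4 as the expected step. The estimate for compound 4 is 8000 nM, between 3000 nM and 30000 nM.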

Compound 4, half-maximal inhibitory concentration: 2200 nM
The estimate for compound 4 lay 3.6-fold (0.56 log units) above the measured number; the measured number lies below the stated range.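

In this assay, within the data shown here, methyl in place of hydrogen on an aromatic carbon, para to a large group, gives an at least 2.2-fold lower number from compound 3 to compound 4 (0.35 log units; beyond the scatter) and so the first readable number for a carbon-only aromatic ring here, showing that a change on that ring itself registers, which the earlier whole-ring exchanges could not show. Compound 4 still falls well short of compound 2, with a 24-fold higher number from compound 2 to compound 4 (1.38 log units; beyond the scatter) and with an at least 2.2-fold lower number from compound 1 to compound 4 (0.35 log units; beyond the scatter) on the other side. The first and last of these steps rest on a limit: the limit of > 5000 nM in this assay, at which 2 of the 4 values shown sit. As far as these compounds go, what a chlorine, a methoxy or an amine at the same carbon would do remains open, as does whether a longer chain there would carry the step further.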